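A few compounds are considered here, and "the series" means these few. Any claim that something is new, unique, unknown or untested is made for them only; others in the source may bear on it.

The compounds measured so far:
compound 1, `CCC1(Cc2ccccc2)OS(=O)(=O)C=C1OCc1ccc(OC)cc1`: > 200000 nM
compound 2, `CCC1(Cc2ccccc2)OS(=O)(=O)C=C1OS(=O)(=O)c1ccc(C)cc1`: 109000 nM
compound 3, `CCCC1(Cc2ccccc2)OS(=O)(=O)C=C1OCc1ccccc1`: 200000 nM

In an ADME assay on HEL cells (Homo sapiens) for cytotoxicity, with a stated time of 3 days (a lower number here means that less compound is tolerated, a higher number that more compound is tolerated), compound 1 gives > 200000 nM, which is a limit of the assay and not a number. Compound 1 thus stands at the limit of > 200000 nM in this assay, at which 1 of the 3 values shown sits. Within this assay, compound 2 shows 109000 nM and compound 3 shows 200000 nM; these two values lie within the scatter of each other, and compound 1 sits at the top of the three.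

Compound 4, `CCC1(Cc2ccccc2)OS(=O)(=O)C=C1OCc1ccc(C)cc1`, differs from compound 1 in one place: methyl in place of methoxy on an aromatic carbon. No measured pair carries this same change, so nothing shown tells the size of the step it brings in this assay. Given that compound 1 stands at a limit, a step of no more than the scatter, in either direction, is expected.

For compound 4 the expected value in this assay is 200000 nM, with a range from 100000 nM to 400000 nM. The step this estimate means, a number no higher from compound 1 to compound 4 (the limit leaves the size open), is expected to stay within the scatter. A reading that is again only a limit is considered likely.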

Compound 4, half-maximal cytotoxic concentration: 41500 nM
For compound 4 the middle estimate is 4.8-fold (0.68 log units) above the measured one, outside the stated range (below it).
By their numbers in this assay, from the lowest: compound 4; then compounds 2 and 3 (each within the scatter of the next).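

In this assay, the change from 4-methoxyphenyl to 4-methylphenyl gives the first step shown at this position, and it is not a silent one: an at least 4.8-fold lower number from compound 1 to compound 4 (0.68 log units; beyond the scatter). The group on this aromatic carbon, para to a large group, can therefore shift the tolerated concentration beyond the scatter, even though the swap removes only one heavy atom and one hydrogen-bond acceptor. The full size of the step cannot be read, because compound 1 stands at a limit of the assay: the limit of > 200000 nM in this assay, at which 1 of the 4 values shown sits.

Among the compounds shown here, only this single pair speaks to the position, so it remains open how a chlorine, a hydroxyl or an amine on the same carbon would read. Also open, as far as these compounds go, is whether the same change would bring a step of similar size with a longer chain on the core.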